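This account rests on a few compounds, and the source may have more. Where it says the series, first, only, none or still open, it means among the compounds named here.

Measured in a functional assay on SK-BR-3 cells (Homo sapiens) for antiproliferative activity; on this read-out lower numbers stand for stronger inhibition and higher numbers for weaker inhibition:
- compound 1 `CC(C)=CCc1cc(C(=O)Nc2cc3ccc(OCC4CCN(C)C4)c(C)c3oc2=O)ccc1O` gives 920 nM
- compound 2 `CC(C)=CCc1cc(C(=O)Nc2cc3ccc(OCCCNCC(C)C)c(C)c3oc2=O)ccc1O` gives 1030 nM
- compound 3 `CC(C)=CCc1cc(C(=O)Nc2cc3ccc(OCCCNC4CCCCC4)c(C)c3oc2=O)ccc1O` gives 660 nM

Compound 3 lies within the usual scatter of both other compounds, so these numbers do not separate the three. Compound 4 `CC(C)=CCc1cc(C(=O)Nc2cc3ccc(OCCCN[C@@H]4C[C@H]5CC[C@@H]4C5)c(C)c3oc2=O)ccc1O` differs from compound 3 at a single place, on the amine nitrogen: a group of 7 heavy atoms (7 carbon; 2 five-membered non-aromatic rings of carbon only) in place of a group of 6 heavy atoms (6 carbon; one six-membered non-aromatic ring of carbon only), on an amine nitrogen (the rest of the structure is shared).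

The closest evidence is the exchange of isobutyl for cyclohexyl on that same nitrogen (a 1.6-fold lower number from compound 2 to compound 3 (0.19 log units; within the scatter)), a step within the scatter. The two larger exchanges, starting from the 1-methylpyrrolidin-3-yl group of compound 1 (a 1.1-fold higher number from compound 1 to compound 2 (0.05 log units; within the scatter) and a 1.4-fold lower number from compound 1 to compound 3 (0.14 log units; within the scatter)), also stay within it. Among these three compounds, then, quite different groups at this end of the molecule have produced no clear shift, and none of them goes against that. For the measured compounds named here, no compound carrying the new two-ring group has been measured yet, so this is only a modest guide.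

No step beyond the scatter is therefore expected in this assay. The estimate is a small one (a 1.1-fold lower number from compound 3 to compound 4 (0.04 log units; within the scatter)) and is expected to be indistinguishable from no change. Compound 4 is expected near 600 nM, with an estimated range from 260 nM to 1400 nM for the measurement.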

Compound 4, half-maximal inhibitory concentration: 770 nM
Compound 4: middle estimate off by 1.3-fold (0.11 log units), on the low side; low and high end bracket the measured number.
By their numbers in this assay, from the lowest: compounds 3, 4, 1 and 2 (each within the scatter of the next).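

In this assay, putting the two-ring group with its 3 defined stereocentres on the amine nitrogen in place of cyclohexyl leaves the result within the scatter (a 1.2-fold higher number from compound 3 to compound 4 (0.07 log units; within the scatter)). The same holds when compound 4 is set against the compound with isobutyl on that nitrogen (a 1.3-fold lower number from compound 2 to compound 4 (0.13 log units; within the scatter)) and against the compound with the 1-methylpyrrolidin-3-yl group (a 1.2-fold lower number from compound 1 to compound 4 (0.08 log units; within the scatter)), so a two-ring carbon group now joins an open chain and a single ring as groups that produce no clear shift, and none of the four compounds goes against this. Nothing available here offers an explanation for this lack of separation.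

As far as these compounds go, all four compounds keep an amine nitrogen at this end of the molecule, so it remains open whether a carboxylic acid or a hydroxyl group in its place would move the number beyond the scatter. Also open, from the compounds shown here alone, is whether the mirror-image form of the two-ring group would behave like compound 4, which would show whether its stereocentres matter at all in this assay.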